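The compounds below may be only part of what the source reports. "The series", "measured", "known", "first", "only" and "open" are said of these compounds alone.

Measured compounds:
compound 1 `COc1cc(Nc2ncnc3c(NC(=O)Nc4cc(Cl)c(Cl)cc4Cl)cccc23)cc(OC)c1` — in a functional assay on RT-112 cells (Homo sapiens) for antiproliferative activity, read by MTT assay, with a stated time of 72 h (on this read-out lower numbers stand for stronger inhibition of growth and higher numbers for weaker inhibition of growth), compound 1 gives 4890 nM.
compound 2 `COc1cc(Nc2ncnc3c(NC(=O)Nc4ccc(Cl)c(C(F)(F)F)c4)cccc23)cc(OC)c1` — in this assay compound 2 reaches only the assay limit, > 20000 nM.
compound 3 `COc1cc(Nc2ncnc3c(NC(=O)Nc4ccc(F)cc4C(F)(F)F)cccc23)cc(OC)c1` — in this assay compound 3 gives 2970 nM.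

Compound 2 thus stands at the weak end of the three, sitting on the limit (the limit of > 20000 nM in this assay, at which 1 of the 3 values shown sits); its entry is a limit, not a number. Compound 4 `COc1cc(Nc2ncnc3c(NC(=O)Nc4ccc(C(F)(F)F)cc4)cccc23)cc(OC)c1` differs from compound 2 by 4-(trifluoromethyl)phenyl in place of 4-chloro-3-(trifluoromethyl)phenyl on an amide-type nitrogen. Among the compounds with values here, two measured steps bear on this change, both leaving or reaching the same group: an at least 6.7-fold lower number from compound 2 to compound 3 (0.82 log units; beyond the scatter) and an at least 4.0-fold higher number from compound 1 to compound 2 (0.61 log units; beyond the scatter). Both place the 4-chloro-3-(trifluoromethyl)phenyl at the weak end, so moving off it is expected to lower the number, though the limit leaves the size open. Compound 4 is estimated at 9000 nM, with a range from 3000 nM to 30000 nM. The expected step is an at least 2.2-fold lower number from compound 2 to compound 4 (0.34 log units; beyond the scatter).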

Compound 4, concentration for 50% growth inhibition: 3920 nM
The estimate for compound 4 lay 2.3-fold (0.36 log units) above the measured number, within the range that was stated.
By their numbers in this assay, from the lowest: compounds 3, 4 and 1 (each within the scatter of the next). At a limit, above all of these: compound 2.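

In this assay, an at least 5.1-fold lower number from compound 2 to compound 4 (0.70 log units; beyond the scatter). From the compounds shown here alone, the entry for compound 2 is a limit, not a number, so the full size of this step stays open: the limit of > 20000 nM in this assay, at which 1 of the 4 values shown sits. With a 1.3-fold higher number from compound 3 to compound 4 (0.12 log units; within the scatter) and a 1.2-fold lower number from compound 1 to compound 4 (0.10 log units; within the scatter), the 4-(trifluoromethyl)phenyl group joins the two other groups within the scatter, leaving 4-chloro-3-(trifluoromethyl)phenyl alone at the weak end.

The compounds shown do not separate a contribution of the chlorine in compound 2 from that of where its trifluoromethyl group sits. Going by these compounds, what a phenyl carrying an amine or a carboxylic acid would give on this nitrogen also stays open.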